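The source may hold more compounds than are shown below. What is called first, only, known or untested is meant among the compounds shown, and "the series" means these compounds.

Measured in a functional assay on MV4-11 cells (Homo sapiens) for inhibition, read by resazurin assay, with a stated time of 72 h; a higher number here means a weaker inhibitor of growth, a lower number a stronger inhibitor of growth:
Compound 1 `O=C1NCCC12CCN(c1c(Cl)cncc1-c1ccco1)CC2`: 940 nM
Compound 2 `Cc1ccc(-c2cncc(Cl)c2N2CCC3(CCNC3=O)CC2)o1`: 4950 nM
Compound 3 `CCOCOCc1ccc(-c2cncc(Cl)c2N2CCC3(CCNC3=O)CC2)o1`: 2970 nM

Compound 2 stands at the high end of these numbers, together with compound 3. The two lie within the scatter of each other, at a 1.7-fold lower number from compound 2 to compound 3 (0.22 log units; within the scatter). Compound 1 has the clearly lower number, and the gap is a 5.3-fold higher number from compound 1 to compound 2 (0.72 log units; beyond the scatter).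

The next compound, compound 4 `Cc1ccc(-c2cncc(Cl)c2N2CCC3(CCNC3=O)CC2)s1`, keeps the core of compound 2 and changes one group: 5-methylthiophen-2-yl in place of 5-methylfuran-2-yl on an aromatic carbon. In words, 5-methylthiophen-2-yl stands in place of 5-methylfuran-2-yl on an aromatic carbon of a six-membered aromatic ring with 1 nitrogen.

For the measured compounds named here, no measured step makes this exchange, so the evidence is indirect. Added groups on an aromatic carbon gave modest steps, a 5.3-fold higher number from compound 1 to compound 2 (0.72 log units; beyond the scatter) and a 3.2-fold higher number from compound 1 to compound 3 (0.50 log units; beyond the scatter). Those steps show that this assay responds to changes in this part of the molecule, but they say nothing about swapping oxygen for sulfur in the ring. The group that enters has the same heavy-atom count as the group that leaves, so no step beyond the scatter is expected.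

The expected change is a 1.2-fold lower number from compound 2 to compound 4 (0.09 log units; within the scatter). For compound 4 the estimate is 4000 nM, with an expected range of 1700 nM to 9000 nM.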

Compound 4, concentration for 50% growth inhibition: 650 nM
For compound 4 the middle estimate is 6.2-fold (0.79 log units) above the measured one; the whole stated range lies above it.
By their numbers in this assay, from the lowest: compounds 4 and 1 (each within the scatter of the next); then compounds 3 and 2 (each within the scatter of the next).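

In this assay, 5-methylthiophen-2-yl in place of 5-methylfuran-2-yl gives a 7.6-fold lower number from compound 2 to compound 4 (0.88 log units; beyond the scatter) with the heavy-atom count unchanged, so this position responds to the identity of the hetero atom in the five-membered ring, and not only to groups added to that ring. Comparing 5-methylthiophen-2-yl with the furan-2-yl group gives a 1.4-fold lower number from compound 1 to compound 4 (0.16 log units; within the scatter), which places the two on a level in this assay even though the methylated furan of compound 2 stood clearly apart from compound 1. No measurement at hand accounts for the difference between the sulfur ring and the oxygen ring.

The compounds shown leave open what the methyl group contributes on the sulfur ring, since only the furan pair isolates that group and the plain thiophen-2-yl group would be needed to answer the same question for thiophene. Going by these compounds, it also remains open whether the (ethoxymethoxy)methyl result of compound 3 carries over to the thiophene series, or how an aminomethyl group or a carboxylic acid on the five-membered ring would behave there.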